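The source may report more compounds than this note shows. Statements on the series, on what has been measured and on what is new or still open speak of the compounds shown alone.

Measured compounds:
compound 1, `COc1cc(OC)cc(OCC(=O)O)c1`, gives 171000 ug/mL;
compound 2, `COc1cc(OCC(=O)O)cc(OC)c1OC`, gives 171000 ug/mL;
compound 3, `O=C(O)COCc1ccc(Cl)cc1`, gives 170000 ug/mL.

All three values come from an ADME assay (Homo sapiens) for solubility; a higher number here means a more soluble compound, a lower number a less soluble compound. Compound 1 and compound 2 differ by methoxy in place of hydrogen on an aromatic carbon, and the step of no change at the digits printed from compound 1 to compound 2 (within the scatter). Compound 3 and compound 1 share no single counted difference; the difference between the two cores is not broken down here, and their values lie within the scatter of each other.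

Compound 4, `COc1cc(Cl)ccc1COCC(=O)O`, carries the same kind of change on the core of compound 3: methoxy in place of hydrogen on an aromatic carbon. The surroundings differ, since the earlier change sat ortho to two methoxy groups and para to a carboxymethoxy group, whereas this one sits ortho to a group of 6 heavy atoms and meta to a chloro group.

The step of no change at the digits printed from compound 3 to compound 4 (within the scatter) is expected to be small, resting on the earlier step of no change at the digits printed from compound 1 to compound 2 (within the scatter). Compound 4 is therefore estimated at 170000 ug/mL, between 100000 ug/mL and 200000 ug/mL.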

Compound 4, solubility: 178000 ug/mL
Compound 4: the middle estimate sits 1.0-fold (0.02 log units) below what was measured, within the range that was stated.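

In this assay the change of methoxy in place of hydrogen on an aromatic carbon gave a 1.0-fold higher number from compound 3 to compound 4 (0.02 log units; within the scatter) and the two cores agree on it: the same change on two cores in this assay, no change at the digits printed (within the scatter) from compound 1 to compound 2 and a 1.0-fold higher number (0.02 log units; within the scatter) from compound 3 to compound 4, 1.0-fold (0.02 log units) apart, within the scatter of two such steps.
In these compounds, then, the change carried from one core to the other, at a different place on the ring, with both steps staying within the scatter. This does not show how the change would behave on other cores or at other places, and it gives no cause for the result.

The compounds shown leave open what an amide in place of the carboxylic acid would give in this assay. They also leave open what a longer chain to that acid would give.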